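The compounds below may be only part of what the source reports. "The series", "measured", "known", "first", "only" and "open" are said of these compounds alone.

Measured compounds:
compound 1 `CCCCCCCCCCCCNC(=O)[C@@H](NC(=O)c1cc2ccccc2o1)[C@@H](C)O`, in a functional assay on MCF7 cells (Homo sapiens) for cytotoxicity, read by MTT assay, with a stated time of 48 h (on this read-out higher numbers stand for weaker inhibition and lower numbers for stronger inhibition), compound 1 gives 20900 nM
compound 2 `CCCCCCCCCCCCNC(=O)[C@@H](NC(=O)c1cc2ccccc2[nH]1)[C@@H](C)O`, compound 2 gives 12300 nM
compound 3 `CCCCCCCCCCCCNC(=O)[C@@H](NC(=O)/C=C/c1ccccc1)[C@@H](C)O`; compound 3 reaches only a limit of this assay, > 200000 nM

Compound 1 and compound 2 sit within the scatter of each other in this assay, as the step of a 1.7-fold lower number from compound 1 to compound 2 (0.23 log units; within the scatter) shows; they differ only at the carbonyl-bound ring. Compound 3 stands apart: the steps of an at least 9.5-fold higher number from compound 1 to compound 3 (0.98 log units; beyond the scatter) and an at least 16-fold higher number from compound 2 to compound 3 (1.21 log units; beyond the scatter) both run to the limit (the limit of > 200000 nM in this assay, at which 1 of the 3 values shown sits), so only a bound is known for compound 3. All three measured steps concern the group on the carbonyl carbon.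

Compound 4 `CCCCCCCCCCCCCCNC(=O)[C@@H](NC(=O)c1cc2ccccc2o1)[C@@H](C)O` leaves that side untouched. It differs from compound 1 by ethyl in place of hydrogen on a saturated chain carbon, ten or more bonds along the chain from an amide-type nitrogen. Among the measured compounds shown here, no measured step touches the long alkyl chain, so none of the measured steps bears directly on this change; the only comparisons on record concern a different part of the molecule. The expectation is therefore a step of no size beyond the scatter in this assay from compound 1 to compound 4, with a wide range to reflect the absence of any chain-length comparison. For compound 4 the estimate is 18000 nM, expected between 6000 nM and 60000 nM, which corresponds to an expected step of a 1.2-fold lower number from compound 1 to compound 4 (0.06 log units; within the scatter).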

Compound 4, half-maximal inhibitory concentration: 23400 nM
The estimate for compound 4 lay 1.3-fold (0.11 log units) below the measured number, and the stated range covers the measured number.
By their numbers in this assay, from the lowest: compounds 2, 1 and 4 (each within the scatter of the next). At a limit, above all of these: compound 3.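

In this assay, ethyl in place of hydrogen on a saturated chain carbon, ten or more bonds along the chain from an amide-type nitrogen, gives a 1.1-fold higher number from compound 1 to compound 4 (0.05 log units; within the scatter), so this position accepts the added ethyl without a step beyond the scatter. Among the compounds shown here, this is the first reading on the long alkyl chain, as the earlier steps all concerned the group on the carbonyl carbon. It rests on a single pair carrying 1-benzofuran-2-yl, and nothing on record gives a cause for the result.

From the compounds shown here alone, whether a shorter chain such as octyl behaves in the same way remains open, as does the effect of an amine or a carboxylic acid at the chain end. Also open, going by these compounds, is whether the same ethyl change gives a similar step when 1H-indol-2-yl sits on the carbonyl carbon.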